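This account rests on a few compounds, and the source may have more. Where it says the series, first, only, none or still open, it means among the compounds named here.

The series rests on one shared core, that of compound 1 `C=C[C@@](C)(/C=C/c1ccc(OC(C)=O)cc1)CCC=C(C)C`, carried through esters of increasing chain length. In a functional assay on PC-3 cells (Homo sapiens) for inhibition, with a stated time of 48 h, tested at 50 uM (on this read-out lower numbers stand for less inhibition of growth and higher numbers for more inhibition of growth at the one concentration tested), compound 1 gives 67%. Compound 2 `C=C[C@@](C)(/C=C/c1ccc(OC(=O)CCCCCCC)cc1)CCC=C(C)C` differs from compound 1 by hexyl in place of hydrogen on a saturated chain carbon bound to a carbonyl carbon; in this assay compound 2 gives 22%, and the step is a number 45 percentage points lower from compound 1 to compound 2 (beyond the scatter). Compound 3 `C=C[C@@](C)(/C=C/c1ccc(OC(=O)CCCCCCCCC)cc1)CCC=C(C)C` differs from compound 1 by octyl in place of hydrogen on a saturated chain carbon bound to a carbonyl carbon; in this assay compound 3 gives 50%, so the step is a number 17 percentage points lower from compound 1 to compound 3 (beyond the scatter), while against compound 2 the step is a number 28 percentage points higher from compound 2 to compound 3 (beyond the scatter). Thus lengthening the ester chain does not move the read-out in one steady direction among these three compounds.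

Compound 4 `C=C[C@@](C)(/C=C/c1ccc(OC(=O)CCCCCCCCCCCCCCC)cc1)CCC=C(C)C` has not yet been measured. It differs from compound 3 by hexyl in place of hydrogen on a saturated chain carbon, nine bonds along the chain from a carbonyl carbon. Among the compounds with values here, this is the same kind of change as the one from compound 1 to compound 2, where hexyl also replaced hydrogen, but the place is not the same: in the earlier case the saturated chain carbon was bound to a carbonyl carbon, whereas here it lies nine bonds along the chain from a carbonyl carbon. The earlier occurrence gave the large step of a number 45 percentage points lower from compound 1 to compound 2 (beyond the scatter). A smaller downward step is expected here, because the further lengthening seen in a number 28 percentage points higher from compound 2 to compound 3 (beyond the scatter) ran upward and the chain end is now far from the carbonyl. The expected step is a number 15 percentage points lower from compound 3 to compound 4 (beyond the scatter). Compound 4 is therefore estimated to give 35%, with a likely range from 10% to 60%.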

Compound 4, percent growth inhibition at one concentration: 62%
Compound 4: middle estimate off by 27 percentage points, on the low side, and the stated range ends below it.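

In this assay, hexyl in place of hydrogen on a saturated chain carbon, nine bonds along the chain from a carbonyl carbon, gives a number 12 percentage points higher from compound 3 to compound 4 (beyond the scatter), and the octyl change gives a number 40 percentage points higher from compound 2 to compound 4 (beyond the scatter); the hexyl change thus does not keep the direction it had on the saturated chain carbon bound to a carbonyl carbon: the same change on two cores in this assay, a number 45 percentage points lower (beyond the scatter) from compound 1 to compound 2 and a number 12 percentage points higher (beyond the scatter) from compound 3 to compound 4, 57 percentage points apart, beyond the scatter of two such steps. The octyl change does not carry over from one core to the other either: the same change on two cores in this assay, a number 17 percentage points lower (beyond the scatter) from compound 1 to compound 3 and a number 40 percentage points higher (beyond the scatter) from compound 2 to compound 4, 57 percentage points apart, beyond the scatter of two such steps. Within the data shown here, in this series, then, the step for a chain extension made on one core cannot be transferred to another, but these steps do not show what lies behind the reversal, and each change is seen on only two cores and at the one concentration tested.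

The compounds shown leave open how the read-out runs for chains of intermediate length between those of compound 3 and compound 4, and for a longer chain than that of compound 4. They also leave open what an amide or a free hydroxyl group in place of the ester would give on the shared core.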